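Free hydroxyls on the benzyl arm and cytotoxicity

The source may report more compounds than this note shows. Statements on the series, on what has been measured and on what is new or still open speak of the compounds shown alone.

Three compounds have been measured in a functional assay on P388 cells (Mus musculus) for cytotoxicity; a lower number here means a stronger inhibitor, a higher number a weaker inhibitor:

Compound 1 `Cc1cc(-c2c(F)cc3c(=O)c(Cc4cccc(O)c4)cn(C4CC4)c3c2F)cc(C)n1` gives 2200 nM.
Compound 2 `COc1cccc(Cc2cn(C3CC3)c3c(F)c(-c4cc(C)nc(C)c4)c(F)cc3c2=O)c1` gives 20000 nM.
Compound 3 `COc1ccccc1Cc1cn(C2CC2)c2c(F)c(-c3cc(C)nc(C)c3)c(F)cc2c1=O` gives 37000 nM.

Compound 3 stands highest of the three numbers. Its nearest step is small: a 1.9-fold higher number from compound 2 to compound 3 (0.27 log units; within the scatter). Its furthest step is large: a 17-fold higher number from compound 1 to compound 3 (1.23 log units; beyond the scatter).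

Compound 4 `Cc1cc(-c2c(F)cc3c(=O)c(Cc4c(O)cc(O)cc4O)cn(C4CC4)c3c2F)cc(C)n1` differs from compound 3 in one place: 2,4,6-trihydroxyphenyl in place of 2-methoxyphenyl on a saturated chain carbon bound to an aromatic carbon.

The measured step that bears on this is a 9.1-fold higher number from compound 1 to compound 2 (0.96 log units; beyond the scatter), where methyl replaced hydrogen on an oxygen on an aromatic ring and the number rose. In compound 4 the methyl leaves and three free hydroxyl groups enter, a change larger than any measured step, so the expectation is loose. Compound 4 is therefore expected to show a lower number, a 4.6-fold lower number from compound 3 to compound 4 (0.67 log units; beyond the scatter). The estimate for compound 4 is 8000 nM, expected to fall between 1500 nM and 40000 nM.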

Compound 4, half-maximal inhibitory concentration: 470 nM
Compound 4: middle estimate off by 17-fold (1.23 log units), on the high side; measured number below the stated range.
By their numbers in this assay, from the lowest: compound 4; then compound 1; then compounds 2 and 3 (each within the scatter of the next).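

Free hydroxyls on this arm do more than the methyl-to-hydrogen step suggested: 2,4,6-trihydroxyphenyl on the saturated chain carbon brings a large drop against both methoxy compounds (a 79-fold lower number from compound 3 to compound 4 (1.90 log units; beyond the scatter); a 43-fold lower number from compound 2 to compound 4 (1.63 log units; beyond the scatter)). It also improves on 3-hydroxyphenyl (a 4.7-fold lower number from compound 1 to compound 4 (0.67 log units; beyond the scatter)), so compound 4 has the lowest number of the four. No evidence is available to explain this drop.

The compounds shown leave open whether all the hydroxyls of 2,4,6-trihydroxyphenyl are needed. They also leave open how an amine or a carboxylic acid on that ring would compare.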